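Second ring chloro on the cyanoguanidine series

This account rests on a few compounds, and the source may have more. Where it says the series, first, only, none or still open, it means among the compounds named here.

Going by the values given here, compound 3 `CC(C)(C)/N=C(\NC#N)Nc1cccnc1Cl` gives 5 mg/kg in a functional assay on the whole organism (blood, strain Wistar-Okamoto) with Rattus norvegicus as the target, with a stated time of 5 days (a higher number here means that more compound is needed for the effect, a lower number that less compound is needed), the second highest of the three numbers measured so far. Compound 1 `CCC(C)/N=C(\NC#N)Nc1cccnc1` gives 20 mg/kg and compound 2 `CCCC(C)(C)/N=C(\NC#N)Nc1cccnc1` gives 1 mg/kg; compound 3 stands lower than compound 1 and higher than compound 2, both gaps beyond the scatter. Among the compounds with values here, compound 1 and compound 3 differ in more than one place, so their values are set side by side only, with no single step between them.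

Compound 4 `CC(C)(C)/N=C(\NC#N)Nc1ccc(Cl)nc1Cl` differs from compound 3 by chloro in place of hydrogen on an aromatic carbon.

Within the data shown here, the only step measured so far, a 20-fold lower number from compound 1 to compound 2 (1.30 log units; beyond the scatter), concerns the group on the double-bonded nitrogen and not the aromatic ring, so it does not bear on this change. Among the measured compounds shown here, no measured pair shows what a second chloro on the ring does; the data give no anchor in either direction. The step from compound 3 to compound 4 is therefore expected to stay within the scatter, with the estimate set at no change at the digits printed from compound 3 to compound 4 (within the scatter).

Compound 4 is estimated at 5 mg/kg in this assay, with a range from 1.5 mg/kg to 15 mg/kg.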

Compound 4, minimum effective dose: > 50 mg/kg
Compound 4: a limit, no number; the forecaster's own chance of this, stated with the estimate: 10%; middle value at least 10-fold (1.00 log units) from the limit.
By their numbers in this assay, from the lowest: compound 2; then compound 3; then compound 1. At a limit, above all of these: compound 4.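

This position, on an aromatic carbon next to the ring nitrogen and meta to the chloro group already present, now has a measured step in this assay: with the group on the double-bonded nitrogen unchanged, chloro in place of hydrogen gives an at least 10-fold higher number from compound 3 to compound 4 (1.00 log units; beyond the scatter) and the step lies beyond the scatter. Going by these compounds alone, the earlier step concerned only the group on the double-bonded nitrogen, so this is the first single change on the ring itself to move the number, and a single added chloro is enough to do so. Compound 4 carries a limit and not a number, so only a lower bound on the size of the step can be read: the limit of > 50 mg/kg in this assay, at which 1 of the 4 values shown sits.

Going by these compounds, whether the change in the number belongs to chloro in particular or to any group at this carbon remains open, and a methyl, a methoxy or an amine in the same place would separate the two. On these data alone, it also remains open whether the same step appears without the existing chloro group, or with 1,1-dimethylbutyl on the double-bonded nitrogen in place of the group compound 4 carries.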